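Swapping the Aryl Group on the Oxygen

This account rests on a few compounds, and the source may have more. Where it says the series, first, only, none or still open, it means among the compounds named here.

Measured in a functional assay with Homo sapiens as the target; on this read-out higher numbers stand for weaker inhibition and lower numbers for stronger inhibition:
- compound 1 `CC(C)[C@H](NC(=O)COc1cccc2ccccc12)C(=O)N[C@@H](CC(=O)O)C(=O)COc1ccccc1[N+](=O)[O-]`: 27700 nM
- compound 2 `CC(C)[C@H](NC(=O)COc1cccc2ccccc12)C(=O)N[C@@H](CC(=O)O)C(=O)COc1c(F)c(F)cc(F)c1F`: 6250 nM

Of these two, compound 2 has the lower number and so the stronger inhibition. Compound 3 `CC(C)[C@H](NC(=O)COc1cccc2ccccc12)C(=O)N[C@@H](CC(=O)O)C(=O)COc1cccc(C(F)(F)F)c1F` has not been measured yet. It keeps the core of compound 2 and changes one group: 2-fluoro-3-(trifluoromethyl)phenyl in place of 2,3,5,6-tetrafluorophenyl on an oxygen on a saturated carbon. In words, 2-fluoro-3-(trifluoromethyl)phenyl takes the place of 2,3,5,6-tetrafluorophenyl on the same oxygen.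

Within the data shown here, only one measured step bears on this, and it changed the group at that same place: a 4.4-fold lower number from compound 1 to compound 2 (0.65 log units; beyond the scatter). That step was modest, so a similarly modest change is a reasonable expectation here, though a single step is thin evidence. Among the measured compounds shown here, since compound 2 holds the lower of only two values, a rise is somewhat likelier than a fall. The expected change is a 1.6-fold higher number from compound 2 to compound 3 (0.20 log units; within the scatter). For compound 3 the estimated value is 10000 nM, with an expected range from 3000 nM to 30000 nM.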

Compound 3, half-maximal inhibitory concentration: 18200 nM
The estimate for compound 3 lay 1.8-fold (0.26 log units) below the measured number; measured number inside the range.
By their numbers in this assay, from the lowest: compound 2; then compounds 3 and 1 (each within the scatter of the next).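

In this assay the step of a 2.9-fold higher number from compound 2 to compound 3 (0.46 log units; beyond the scatter) shows that this position responds to more than the count of fluorine atoms: both groups carry the same count on one six-membered aromatic ring, yet the numbers separate beyond the scatter. The step of a 1.5-fold lower number from compound 1 to compound 3 (0.18 log units; within the scatter) stays within the scatter, so the 2-fluoro-3-(trifluoromethyl)phenyl and 2-nitrophenyl groups cannot be told apart on this read-out. Among these three compounds, only the 2,3,5,6-tetrafluorophenyl group of compound 2 stands apart from both others, though nothing measured here explains this difference.

On these data alone, it remains open how a plain phenyl group, or a phenyl ring carrying an amine or a carboxylic acid, would behave on this oxygen. It is also unclear whether a saturated ring such as cyclohexyl would be tolerated there at all.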